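The source may report more compounds than this note shows. Statements on the series, on what has been measured and on what is new or still open speak of the compounds shown alone.

Measured so far in a functional assay on CWR22R cells (Homo sapiens) for antiproliferative activity, read by propidium iodide staining, with a stated time of 96 h; a lower number here means a stronger inhibitor, a higher number a weaker inhibitor:

- compound 1 `CC(O)(CSc1cccc(S(F)(F)(F)(F)F)c1)C(=O)Nc1ccc(C#N)c(C(F)(F)F)c1`: 20400 nM
- compound 2 `CC(O)(CSc1ccc(S(F)(F)(F)(F)F)cc1)C(=O)Nc1ccc(S(F)(F)(F)(F)F)cc1`: 24400 nM
- compound 3 `CC(O)(CSc1ccc(C(F)(F)F)cc1)C(=O)Nc1ccc(S(F)(F)(F)(F)F)cc1`: 14800 nM

In this assay compound 3 gives 14800 nM, which lies within the usual scatter of the values for both compound 1 and compound 2. The three measured compounds therefore cannot be ranked with confidence.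

The next compound is compound 4 `CC(O)(CSc1ccccc1C(F)(F)F)C(=O)Nc1ccc(S(F)(F)(F)(F)F)cc1`, which has the same atoms as compound 3 joined differently. It carries 2-(trifluoromethyl)phenyl in place of 4-(trifluoromethyl)phenyl on a sulfur.

Among the measured compounds shown here, only one measured step offers any guidance. This is a 1.6-fold lower number from compound 2 to compound 3 (0.22 log units; within the scatter), a group exchange on an aromatic carbon that stays within the scatter. For the measured compounds named here, it is indirect evidence, since no measured pair shows what moving a group around the ring does. With so little to go on, no change beyond the scatter is expected, and the expected step is a 1.1-fold higher number from compound 3 to compound 4 (0.03 log units; within the scatter).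

For compound 4 the estimate is 16000 nM, with an expected range from 7000 nM to 35000 nM.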

Compound 4, half-maximal inhibitory concentration: 13200 nM
Estimate against measurement, compound 4: 1.2-fold (0.08 log units) above; low and high end bracket the measured number.
By their numbers in this assay, from the lowest: compounds 4, 3, 1 and 2 (each within the scatter of the next).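

In this assay, among the compounds shown here, compound 3 and compound 4 form the first measured pair with the same atoms joined differently, and 2-(trifluoromethyl)phenyl in place of 4-(trifluoromethyl)phenyl on a sulfur gives a 1.1-fold lower number from compound 3 to compound 4 (0.05 log units; within the scatter). For this pair, then, where the trifluoromethyl group sits on the ring attached to the sulfur makes no difference that the assay can separate from ordinary scatter. No measurement here offers an explanation for this result.

Still open, as far as these compounds go, is whether a ring carrying an amine or a carboxylic acid in place of trifluoromethyl, or a longer chain in place of the ring on this sulfur, would move the number beyond the scatter. From the compounds shown here alone, it is also open whether the same exchange would read alike on the core of compound 1, with its nitrile-bearing ring.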